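Removing the Methoxy Group: Expectation for Compound 4

A few compounds are considered here, and "the series" means these few. Any claim that something is new, unique, unknown or untested is made for them only; others in the source may bear on it.

Measured compounds in this series:
compound 1, `COc1ccc(Nc2nnc(Nc3nc(-c4ccc(Cl)cc4)cs3)s2)cc1`, 300 mg/kg
compound 2, `COc1ccccc1Nc1nnc(Nc2nc(-c3ccccc3)cs2)s1`, 300 mg/kg
compound 3, `COc1ccc(Nc2nnc(Nc3nc(-c4ccccc4)cs3)s2)cc1`, 300 mg/kg

All three were tested in a functional assay on the whole organism (strain albino) with Mus musculus as the target, with a stated time of 4 h; on this read-out higher numbers stand for an effect only at larger amounts of compound and lower numbers for an effect already at smaller amounts. Compound 1 `COc1ccc(Nc2nnc(Nc3nc(-c4ccc(Cl)cc4)cs3)s2)cc1` gives 300 mg/kg, compound 2 `COc1ccccc1Nc1nnc(Nc2nc(-c3ccccc3)cs2)s1` gives 300 mg/kg, and compound 3 `COc1ccc(Nc2nnc(Nc3nc(-c4ccccc4)cs3)s2)cc1` gives 300 mg/kg. Compound 3 therefore stands level with compounds 1 and 2 at the digits shown. The step of no change at the digits printed from compound 1 to compound 3 (within the scatter), hydrogen in place of chloro on an aromatic carbon, lies within the scatter, and so does the step of no change at the digits printed from compound 2 to compound 3 (within the scatter), 4-methoxyphenyl in place of 2-methoxyphenyl on a nitrogen on an aromatic ring. Neither substituent change shifted the minimum effective dose.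

Compound 4 `c1ccc(Nc2nnc(Nc3nc(-c4ccccc4)cs3)s2)cc1` has not yet been measured. It differs from compound 3 by hydrogen in place of methoxy on an aromatic carbon. Among the measured compounds shown here, no measured step removes a methoxy group, so nothing bears on it directly; the two measured steps, each a small change of a substituent on one of the outer phenyl groups, both left the read-out unchanged. On that basis no step beyond the scatter is expected in this assay for the change from compound 3 to compound 4. Compound 4 is expected to give about 300 mg/kg, with a range from 150 mg/kg to 600 mg/kg, an estimated step of no change at the digits printed from compound 3 to compound 4 (within the scatter).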

Compound 4, minimum effective dose: 100 mg/kg
Beside the measured number, compound 4's estimate is 3.0-fold (0.48 log units) above it; the whole stated range lies above it.
By their numbers in this assay, from the lowest: compound 4; then compounds 1, 2 and 3 (each within the scatter of the next).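

In this assay, among the compounds shown here, the methoxy group on this outer phenyl ring, para to a large group, is the first feature whose change takes the read-out beyond the scatter: replacing it with hydrogen gives a 3.0-fold lower number from compound 3 to compound 4 (0.48 log units; beyond the scatter) and a lower dose is enough. The same replacement starting from the other methoxy placing gives a 3.0-fold lower number from compound 2 to compound 4 (0.48 log units; beyond the scatter) and so lands on the same result, which shows that compound 2 and compound 3 stand level while the compound without methoxy stands apart from both. Shifting the methoxy group around this ring therefore left the read-out unchanged, whereas taking it away did not, although no information is available here to explain this difference.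

The compounds shown leave open whether a smaller group such as fluoro or methyl, or a hydroxyl or an amine, at this place would read like methoxy or like hydrogen. They also leave open whether the chloro group on the other phenyl ring, which made no difference with methoxy present, would still make none on the phenyl scaffold of compound 4.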